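The source may report more compounds than this note shows. Statements on the series, on what has been measured and on what is new or still open speak of the compounds shown alone.

Measured compounds:

Compound 1 `CCc1c(OCc2ccccc2)c(=O)ccn1CCCNc1ccnc2cc(Cl)ccc12` — 15000 nM
Compound 2 `CCc1c(OCc2ccccc2)c(=O)ccn1CCCCNc1ccnc2cc(Cl)ccc12` — 9000 nM
Compound 3 `CCc1c(O)c(=O)ccn1CCCNc1ccnc2cc(Cl)ccc12` — 55000 nM

Of the compounds shown here, three have been measured in an ADME assay on KB cells (Homo sapiens) for cytotoxicity, read by resazurin assay, with a stated time of 72 h; a higher number here means a weaker inhibitor, a lower number a stronger inhibitor. Compound 1 `CCc1c(OCc2ccccc2)c(=O)ccn1CCCNc1ccnc2cc(Cl)ccc12` gives 15000 nM in this assay. Compound 2 `CCc1c(OCc2ccccc2)c(=O)ccn1CCCCNc1ccnc2cc(Cl)ccc12` gives 9000 nM, which is within the scatter of compound 1; the difference between the cores of compound 1 and compound 2 is not broken down here. Compound 3 `CCc1c(O)c(=O)ccn1CCCNc1ccnc2cc(Cl)ccc12` gives 55000 nM. Going by the values given here, the one counted change in the set, (hydrogen in place of benzyl on an oxygen on an aromatic ring), produced a 3.7-fold higher number from compound 1 to compound 3 (0.56 log units; beyond the scatter).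

Compound 4 `CCc1c(O)c(=O)ccn1CCCCNc1ccnc2cc(Cl)ccc12` has not yet been measured in this assay. It differs from compound 2 by hydrogen in place of benzyl on an oxygen on an aromatic ring, the same change that separates compound 1 from compound 3, made at a place described in the same words. The only basis for an expectation is therefore that single measured step. For compound 4 a step of a 3.7-fold higher number from compound 2 to compound 4 (0.56 log units; beyond the scatter) is expected, resting on the step from compound 1 to compound 3 of a 3.7-fold higher number from compound 1 to compound 3 (0.56 log units; beyond the scatter), with the caveat that the cores of compound 2 and compound 4 carry a difference that is not broken down here, so the step may not transfer exactly. On that basis compound 4 is estimated at 33000 nM in this assay, with a plausible range from 15000 nM to 75000 nM.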

Compound 4, half-maximal inhibitory concentration: 76000 nM
The estimate for compound 4 lay 2.3-fold (0.36 log units) below the measured number; measured number above the stated range.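

The benzyloxy to hydroxy change, read on a second core in this assay, gives an 8.4-fold higher number from compound 2 to compound 4 (0.93 log units; beyond the scatter), so the direction seen on the first core holds here as well. Set side by side, the two steps do not separate in size, and the change can be carried between these two cores without a measurable shift: the same change on two cores in this assay, a 3.7-fold higher number (0.56 log units; beyond the scatter) from compound 1 to compound 3 and an 8.4-fold higher number (0.93 log units; beyond the scatter) from compound 2 to compound 4, 2.3-fold (0.36 log units) apart, within the scatter of two such steps This rests on two pairs only, so it sets no general rule for the series, gives no reason for the step, and does not support reading the larger printed step on the core of compound 2 as a real effect of that core.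

From the compounds shown here alone, only benzyl and hydrogen appear on this oxygen, so it remains open whether a small group such as methyl, or a benzyl carrying a fluorine or a methoxy group, would keep the number close to that of the benzyl compounds or move it toward that of the hydroxy compounds. Also open, going by these compounds, is whether the step keeps its direction and size on cores with a longer chain, or with an amine or a carboxylic acid added to the chain.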